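The source may report more compounds than this note shows. Statements on the series, on what has been measured and on what is new or still open speak of the compounds shown alone.

Measured compounds:
Compound 1, `NS(=O)(=O)Oc1ccc2c(c1)CN(C(=O)c1ccc(N3CCCCC3)cc1)CC2`: 11.5%
Compound 2, `CN(CCN1CCCCC1)c1ccc(C(=O)N2CCc3ccc(OS(N)(=O)=O)cc3C2)cc1`: 0.3%

In an assay on HEK293 cells for inhibition of Steryl-sulfatase (Homo sapiens), tested at 0.1 uM (on this read-out lower numbers stand for a weaker effect and higher numbers for a stronger effect at the one concentration tested), compound 1 gives 11.5%, while compound 2 gives 0.3%. Going by the values given here, compound 2 therefore stands lowest of the two numbers, and its only neighbour is compound 1, separated from it by the single step measured so far, a number 11.2 percentage points lower from compound 1 to compound 2 (beyond the scatter). That step swapped the whole group on the aromatic carbon, so it is not the same kind of change as the one now considered.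

Compound 3, `CN(CCCN1CCCCC1)c1ccc(C(=O)N2CCc3ccc(OS(N)(=O)=O)cc3C2)cc1`, differs from compound 2 by (piperidin-1-yl)methyl in place of piperidin-1-yl on a saturated chain carbon, two bonds along the chain from a nitrogen on an aromatic ring, which amounts to methyl(3-(piperidin-1-yl)propyl)amino in place of methyl(2-(piperidin-1-yl)ethyl)amino. Among the compounds with values here, no measured step tests a chain lengthening of this kind, and compound 2 already sits at the bottom of the read-out, so the expected change is a number 1.7 percentage points higher from compound 2 to compound 3 (within the scatter), that is none beyond the scatter. Compound 3 is accordingly estimated at 2%, with a range from 0% to 12%.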

Compound 3, a percentage reported as inhibition, at one concentration (the size of the read-out at that concentration, not a potency): 17.4%
Compound 3: middle estimate off by 15.4 percentage points, on the low side; the measured number lies above the stated range.
By their numbers in this assay, from the lowest: compound 2; then compounds 1 and 3 (each within the scatter of the next).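

In this assay, the length of the chain carrying the piperidine ring matters: changing 2-(piperidin-1-yl)ethyl to 3-(piperidin-1-yl)propyl gives a number 17.1 percentage points higher from compound 2 to compound 3 (beyond the scatter), something compounds 1 and 2 alone could not reveal. Adding a chain on the aromatic carbon therefore does not always lower the read-out: methyl(3-(piperidin-1-yl)propyl)amino in place of piperidin-1-yl gives a number 5.9 percentage points higher from compound 1 to compound 3 (within the scatter), unlike the ethyl version, which gave a number 11.2 percentage points lower from compound 1 to compound 2 (beyond the scatter). Nothing available here explains why the two chains differ.

From the compounds shown here alone, it remains open whether a still longer chain, such as 4-(piperidin-1-yl)butyl, would keep the read-out at this level or move it further. Going by these compounds, it is also open whether the piperidine ring at the chain end is needed, or whether a different amine, such as morpholine, would serve equally well.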